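A Fourth Amide Ring on a Shared Core

The source may report more compounds than this note shows. Statements on the series, on what has been measured and on what is new or still open speak of the compounds shown alone.

Measured so far:
compound 1, `COc1cccc(NC(=O)COc2ccc3cc(/C=C4/SC(=O)NC4=O)ccc3c2)c1` — 1600 nM
compound 2, `Cc1cccc2sc(NC(=O)COc3ccc4cc(/C=C5/SC(=O)NC5=O)ccc4c3)nc12` — 1200 nM
compound 3, `O=C(COc1ccc2cc(/C=C3/SC(=O)NC3=O)ccc2c1)Nc1c(F)cc(F)cc1Br` — 1100 nM

These three values come from an assay on isolated protein for inhibition of histone deacetylase 4 (Homo sapiens), with a stated time of 1 h; on this read-out lower numbers stand for stronger inhibition and higher numbers for weaker inhibition. Compound 3 gives the lowest of the three numbers, yet neither neighbour is separated from it by more than the scatter: a 1.1-fold lower number from compound 2 to compound 3 (0.04 log units; within the scatter) and a 1.5-fold lower number from compound 1 to compound 3 (0.16 log units; within the scatter). The step between the other pair is likewise small, a 1.3-fold lower number from compound 1 to compound 2 (0.12 log units; within the scatter). Across a methoxyphenyl, a methylbenzothiazolyl and a bromodifluorophenyl group on the amide-type nitrogen, the numbers in this assay stay flat.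

Compound 4, `Cc1ccc(NC(=O)COc2ccc3cc(/C=C4/SC(=O)NC4=O)ccc3c2)cc1Cl`, is not yet measured. Its difference from compound 3 is 3-chloro-4-methylphenyl in place of 2-bromo-4,6-difluorophenyl on an amide-type nitrogen. All three measured steps change the same group on the same nitrogen, and all three fall within the scatter, so the change to compound 4 is expected to give no step beyond the scatter either: a 1.2-fold higher number from compound 3 to compound 4 (0.07 log units; within the scatter). On that basis compound 4 is estimated at 1300 nM in this assay, with a range from 600 nM to 2800 nM expected to hold most repeat measurements.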

Compound 4, half-maximal inhibitory concentration: 1100 nM
Compound 4: middle estimate off by 1.2-fold (0.07 log units), on the high side; low and high end bracket the measured number.
By their numbers in this assay, from the lowest: compounds 3, 4, 2 and 1 (each within the scatter of the next).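

Putting 3-chloro-4-methylphenyl in place of 2-bromo-4,6-difluorophenyl on the amide-type nitrogen leaves the number in this assay unchanged (no change at the digits printed from compound 3 to compound 4 (within the scatter)), and the steps from the two other compounds are just as small (a 1.1-fold lower number from compound 2 to compound 4 (0.04 log units; within the scatter)) and (a 1.5-fold lower number from compound 1 to compound 4 (0.16 log units; within the scatter)). The flat reading at this nitrogen now spans four groups with no exception among them, and it also holds when a ring carrying one bromine and two fluorines gives way to one carrying a single chlorine and a methyl group, with one heavy atom fewer. Nothing given here explains why the number stays flat at this position.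

On these data alone, every group on this nitrogen so far is built on an aromatic ring, so it remains open whether a carboxylic acid or an amine on that ring, a saturated piperidine ring in its place or a longer chain between ring and nitrogen would produce a step beyond the scatter. The four compounds also share one core and one linking chain, so they say nothing about how changes in those parts would read in this assay.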